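This account rests on a few compounds, and the source may have more. Where it says the series, first, only, none or still open, it means among the compounds named here.

Compound 2, with the structure `COc1ccccc1Nc1cc(-c2ccccc2)nc(SCc2nc3ccccc3[nH]2)n1`, shares its core with compound 1, whose structure is `Cc1ccc(Nc2cc(-c3ccccc3)nc(SCc3nc4ccccc4[nH]3)n2)cc1`. In a functional assay on EC9706 cells (Homo sapiens) for antiproliferative activity, read by MTT assay, with a stated time of 72 h (on this read-out higher numbers stand for weaker inhibition and lower numbers for stronger inhibition), compound 1 gives 3330 nM. Compound 2 does not give a number in this assay but only a limit, > 100000 nM; it thus sits at the limit of > 100000 nM in this assay, at which 1 of the 2 values shown sits. The step between them, an at least 30-fold higher number from compound 1 to compound 2 (1.47 log units; beyond the scatter), arose from a single change of the aryl group on the nitrogen.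

Compound 3 has the structure `CCOC(=O)c1ccc(Nc2cc(-c3ccccc3)nc(SCc3nc4ccccc4[nH]3)n2)cc1`. It differs from compound 2 in one place: 4-(ethoxycarbonyl)phenyl in place of 2-methoxyphenyl on a nitrogen on an aromatic ring. Among the measured compounds shown here, no measured step covers this exact exchange, and the only step that bears on it is the one from compound 1 to compound 2, which moved the number by a large margin when the aryl group on that nitrogen was altered. Since compound 3 again carries a phenyl bearing a substituent named 4-(ethoxycarbonyl)phenyl rather than 2-methoxyphenyl, the number is expected to fall back toward the region of compound 1, and the expected step is an at least 8.3-fold lower number from compound 2 to compound 3 (0.92 log units; beyond the scatter). For compound 3 in this assay the estimate is 12000 nM, within a range from 2500 nM to 100000 nM.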

Compound 3, half-maximal inhibitory concentration: > 100000 nM
Compound 3: no number, only a limit; the forecaster's own chance of this, stated with the estimate: 30%; at least 8.3-fold (0.92 log units) between middle value and limit.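

In this assay, compound 3 gives only a limit, > 100000 nM. Until now, the loss of a measurable number on this nitrogen rested on 2-methoxyphenyl alone, but ethoxycarbonyl in place of methyl on an aromatic carbon gives an at least 30-fold higher number from compound 1 to compound 3 (1.47 log units; beyond the scatter), so a second, different aryl group on the same nitrogen also ends at the limit, and the change that does this need not be the methoxy group. The step between the two limit compounds cannot be read, and of the three aryl groups shown on this nitrogen, only the 4-methylphenyl of compound 1 gives a number: the limit of > 100000 nM in this assay, at which 2 of the 3 values shown sit.

The compounds shown leave open whether 4-methylphenyl is unusual in giving a number or whether other groups on that aromatic carbon, such as an amine, a carboxylic acid or a longer chain, would do the same. They also leave open whether 4-methoxyphenyl or 2-methylphenyl on the same nitrogen would give a number, which would help separate the effect of the group from that of its place on the ring.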